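The source may hold more compounds than are shown below. What is called first, only, known or untested is meant among the compounds shown, and "the series" means these compounds.

Measured so far (a functional assay on MCF7 cells (Homo sapiens) for inhibition, read by sulforhodamine B assay; a higher number here means a weaker inhibitor, a lower number a stronger inhibitor):
- compound 1 `O=C1C=C(N2CCC2)C(=O)c2c1nc1n2[C@H]2OC[C@@H](O)[C@H]2OC1`: > 16000 nM (a limit of the assay, not a number)
- compound 2 `Cc1ccc(NC2=CC(=O)c3nc4n(c3C2=O)[C@H]2OC[C@@H](O)[C@H]2OC4)cc1C`: 2080 nM

Among the compounds with values here, compound 2 holds the only actual number, since the sole other result is a limit. Compound 3 `O=C1C=C(Nc2ccccc2)C(=O)c2c1nc1n2[C@H]2OC[C@@H](O)[C@H]2OC1` differs from it at one place (phenyl in place of 3,4-dimethylphenyl on an amine nitrogen), with phenyl in place of 3,4-dimethylphenyl on an amine nitrogen.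

Within the data shown here, the one measured step (an at least 7.6-fold lower number from compound 1 to compound 2 (0.88 log units; beyond the scatter)) replaced azetidin-1-yl with (3,4-dimethylphenyl)amino. It bears only loosely on this change, showing that the substituent at this place can matter. It does not compare phenyl with 3,4-dimethylphenyl. No step beyond the scatter is therefore expected in this assay, in either direction, although a real shift cannot be excluded.

The expected change is a 1.2-fold higher number from compound 2 to compound 3 (0.06 log units; within the scatter). For compound 3 the estimated value is 2400 nM, with an expected range of 900 nM to 6500 nM.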

Compound 3, half-maximal inhibitory concentration: > 4000 nM
Compound 3: only a limit was reported; the forecaster's own chance of this, stated with the estimate: 8%; middle value at least 1.6-fold (0.22 log units) away from the limit.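

In this assay, phenyl in place of 3,4-dimethylphenyl on the amine nitrogen gives an at least 1.9-fold higher number from compound 2 to compound 3 (0.28 log units; that floor lies within the scatter). Compound 3 has only a limit, not a number: the limit of > 4000 nM in this assay, at which 1 of the 3 values shown sits.

Within the data shown here, the floor of this step lies within the scatter, so a real difference between the two aryl groups is not established, though a larger one remains possible; this is the first comparison of two aryl groups at this amine nitrogen.

The step from compound 1 to compound 3 cannot be read, as both ends are limits. Still open, going by these compounds, are the true size of the step from compound 2 to compound 3 and whether a phenyl carrying a single methyl, a methoxy or a carboxylic acid would give a measurable number in this assay.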